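Acetyl on the Amino Group of Compound 3

The compounds below may be only part of what the source reports. "The series", "measured", "known", "first", "only" and "open" are said of these compounds alone.

In a functional assay on K562 cells (Homo sapiens) for inhibition, read by MTT assay, with a stated time of 48 h (a lower number here means a stronger inhibitor, a higher number a weaker inhibitor), compound 1 `Nc1ccc(-c2cn([C@@H]3CN[C@H](C(=O)Nc4ccc(Cl)c(C(F)(F)F)c4)C3)nn2)cn1` gives 10400 nM and compound 2 `CS(=O)(=O)Nc1ccc(-c2cn([C@@H]3CN[C@H](C(=O)Nc4ccc(Cl)c(C(F)(F)F)c4)C3)nn2)cn1` gives 5060 nM while compound 3 `Nc1n[nH]c2cc(-c3cn([C@@H]4CN[C@H](C(=O)Nc5ccc(Cl)c(C(F)(F)F)c5)C4)nn3)ccc12` gives 8320 nM in the same read-out. Compound 3 stands inside the scatter of the other two, since the steps (a 1.3-fold lower number from compound 1 to compound 3 (0.10 log units; within the scatter)) and (a 1.6-fold higher number from compound 2 to compound 3 (0.22 log units; within the scatter)) both lie within it. Compound 4 `CC(=O)Nc1n[nH]c2cc(-c3cn([C@@H]4CN[C@H](C(=O)Nc5ccc(Cl)c(C(F)(F)F)c5)C4)nn3)ccc12` differs from compound 3 by acetyl in place of hydrogen on a nitrogen on an aromatic ring, amino to acetamido (acetyl in place of hydrogen on a nitrogen on an aromatic ring). Going by the values given here, the closest measured change is the one leading to compound 2, with methylsulfonyl in place of hydrogen on a nitrogen on an aromatic ring (a 2.1-fold lower number from compound 1 to compound 2 (0.31 log units; beyond the scatter)), which is modest and just beyond the scatter. Among the compounds with values here, that is a single case on a different aromatic group, and no measured compound carries acetyl. In this assay the expected step is therefore small (a 1.4-fold lower number from compound 3 to compound 4 (0.16 log units; within the scatter)) and toward a lower number, and it may stay within the scatter. For compound 4 the estimated value is 5800 nM with an expected range from 2500 nM to 13000 nM in this read-out.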

Compound 4, half-maximal inhibitory concentration: 15500 nM
Compound 4: the middle estimate sits 2.7-fold (0.43 log units) below what was measured; the whole stated range lies below it.
By their numbers in this assay, from the lowest: compounds 2, 3, 1 and 4 (each within the scatter of the next, the first and the last beyond it).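

In this assay acetyl in place of hydrogen on a nitrogen on an aromatic ring, amino to acetamido, gives a step that stays within the scatter (a 1.9-fold higher number from compound 3 to compound 4 (0.27 log units; within the scatter)), so this position tolerates the acetyl group without a step that can be told from repeat measurement. The only other substitution on such a nitrogen, methylsulfonyl on a different aromatic group, lies just beyond the scatter (a 2.1-fold lower number from compound 1 to compound 2 (0.31 log units; beyond the scatter)), and its step does not carry over to acetyl on this position. Nothing given here explains the acetyl result.

The compounds shown leave open whether methylsulfonyl on this same nitrogen would give a step beyond the scatter. They also leave open whether a longer chain such as butanoyl, or a carboxylic acid at the end of such a chain, would stay within it.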